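The compounds below may be only part of what the source reports. "The series", "measured", "known", "first", "only" and "open" are said of these compounds alone.

Measured compounds:
compound 1 `C[N+]1(CC2CCC2)CCc2c(sc(NC(=O)Nc3ccc(Cl)cc3)c2C(N)=O)C1` gives 210 nM
compound 2 `CC(C)(C)OC(=O)CCCCN1CCc2c(sc(NC(=O)Nc3ccc(Cl)cc3)c2C(N)=O)C1` gives 710 nM

In a functional assay (strain AB) with Danio rerio as the target, read by microscopy, with a stated time of 1 h (on this read-out higher numbers stand for an effect only at larger amounts of compound and lower numbers for an effect already at smaller amounts), compound 1 gives 210 nM, the lower of the two numbers recorded here, while compound 2 gives 710 nM. Compound 3 `CC(C)(C)OC(=O)CCCCC[N+]1(C)CCc2c(sc(NC(=O)Nc3ccc(Cl)cc3)c2C(N)=O)C1` differs from compound 1 by 4-(tert-butoxycarbonyl)butyl in place of cyclobutyl on a saturated chain carbon bound to an amine nitrogen in a ring. Among the compounds with values here, no step between measured compounds has been charted, so the expectation rests on the two values alone. Compound 2 carries the same entering chain and gives 710 nM, the higher number, so a modest upward step is expected for compound 3, a 2.1-fold higher number from compound 1 to compound 3 (0.33 log units; beyond the scatter), beyond the scatter. Compound 3 is therefore estimated at 450 nM, with a range from 180 nM to 1100 nM.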

Compound 3, half-maximal effective concentration: 110 nM
Beside the measured number, compound 3's estimate is 4.1-fold (0.61 log units) above it; measured number outside the range, below it.
By their numbers in this assay, from the lowest: compounds 3 and 1 (each within the scatter of the next); then compound 2.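

In this assay, putting 4-(tert-butoxycarbonyl)butyl in place of cyclobutyl on a saturated chain carbon bound to an amine nitrogen in a ring gives a 1.9-fold lower number from compound 1 to compound 3 (0.28 log units; within the scatter) as its step. This position therefore accepts the larger, ring-free ester chain without a change that this read-out can separate from the scatter. No measurement shown here accounts for this result.

From the compounds shown here alone, whether a free carboxylic acid in place of the tert-butyl ester would behave alike remains open. So does the effect of a shorter or longer chain at this position.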